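Replacing a fluorinated chain with cyclopentyl on the carbonyl

The compounds below may be only part of what the source reports. "The series", "measured", "known", "first", "only" and "open" are said of these compounds alone.

Of the compounds shown here, three sharing one core have been measured in a functional assay on isolated protein for inhibition of Glucose-dependent insulinotropic receptor (Homo sapiens), read by HTRF and cAMP accumulation; a lower number here means that less compound is needed, a higher number that more compound is needed for the effect. Compound 1 `Cc1nc(S(C)(=O)=O)ccc1Oc1ncnc(OC2CCN(C(=O)OC(C)(C)CF)CC2)c1F` gives 19.9 nM and stands as the lowest of the three numbers, though its neighbours sit within the usual scatter. Compound 2 `Cc1nc(S(C)(=O)=O)ccc1Oc1ncnc(OC2CCN(C(=O)OC3(C(F)(F)F)COC3)CC2)c1F` gives 29.3 nM, and compound 3 `Cc1nc(S(C)(=O)=O)ccc1Oc1ncnc(OC2CCN(C(=O)C3(F)CCC3)CC2)c1F` gives 24.7 nM. The steps among them are all small: a 1.5-fold higher number from compound 1 to compound 2 (0.17 log units; within the scatter), a 1.2-fold higher number from compound 1 to compound 3 (0.09 log units; within the scatter) and a 1.2-fold lower number from compound 2 to compound 3 (0.07 log units; within the scatter).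

Compound 4 `Cc1nc(S(C)(=O)=O)ccc1Oc1ncnc(OC2CCN(C(=O)C3CCCC3)CC2)c1F` has not yet been measured. It differs from compound 1 in one place: a group of 5 heavy atoms (5 carbon; one five-membered non-aromatic ring of carbon only) in place of a group of 6 heavy atoms (4 carbon, 1 oxygen, 1 fluorine; no ring), on a carbonyl carbon. Going by the values given here, the closest precedent is the step of a 1.2-fold higher number from compound 1 to compound 3 (0.09 log units; within the scatter), where a small carbon ring carrying a fluorine also took the place of the same chain on the carbonyl carbon and the number barely moved. The step of a 1.5-fold higher number from compound 1 to compound 2 (0.17 log units; within the scatter) likewise shows that varying this end of the molecule changed little. Compound 4 is therefore expected to stay close to compound 1, with an estimated step of a 1.3-fold higher number from compound 1 to compound 4 (0.12 log units; within the scatter). The expected value for compound 4 in this assay is 26 nM, within a range of 11 nM to 60 nM.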

Compound 4, half-maximal effective concentration: 72.8 nM
Estimate against measurement, compound 4: 2.8-fold (0.45 log units) below, outside the stated range (above it).
By their numbers in this assay, from the lowest: compounds 1, 3 and 2 (each within the scatter of the next); then compound 4.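

In this assay, going by these compounds alone, the cyclopentyl group is the first change on this carbonyl carbon to go beyond the scatter, with a 3.7-fold higher number from compound 1 to compound 4 (0.56 log units; beyond the scatter) and a 2.9-fold higher number from compound 3 to compound 4 (0.47 log units; beyond the scatter) and also a 2.5-fold higher number from compound 2 to compound 4 (0.40 log units; beyond the scatter) among the four compounds. This position therefore does respond to what it carries, even though the three earlier groups could not be told apart. No measurement shown here accounts for the rise.

Compound 3 and compound 4 differ in both ring size and the fluorine, so these two features cannot be separated; a cyclobutyl group without fluorine or a 1-fluorocyclopentyl group would pull them apart. Also open, on these data alone, is how a cyclohexyl group or an open carbon chain such as tert-butyl would behave on the same carbonyl carbon.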